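This account rests on a few compounds, and the source may have more. Where it says the series, first, only, none or still open, it means among the compounds named here.

Of the compounds shown here, three have been measured so far in an assay on COS-7 cells for inhibition of patatin-like phospholipase domain-containing protein 2 (Mus musculus); on this read-out higher numbers stand for weaker inhibition and lower numbers for stronger inhibition. Compound 1 `CCOC(=O)c1ccnc(-c2ccc(OCC)cc2)c1` gives 80000 nM in this assay. Compound 2 `CCOC(=O)c1cncc(-c2ccc(OCC)cc2)c1` gives 130000 nM in this assay. Compound 3 `CCOC(=O)c1cccc(-c2ccc(C)cc2)c1` gives 140000 nM in this assay. Of these three numbers, compound 3 carries the highest, yet its gap to compound 2 and its gap to compound 1 both lie within the usual scatter of repeated measurements, so on this read-out the three compounds cannot be told apart; all of them sit in a weak region.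

Compound 4 `CCOC(=O)c1cccc(-c2ccc(C(C)N(C)C)cc2)c1` has not yet been measured. It differs from compound 3 in a single place: 1-(dimethylamino)ethyl in place of methyl on an aromatic carbon. Within the data shown here, no pair of measured compounds shows this change, so its size and direction cannot be read from the data. The expected step is a 2.8-fold lower number from compound 3 to compound 4 (0.45 log units; beyond the scatter), a modest move toward stronger inhibition rather than none beyond the scatter, though a result that stays within the scatter would not be surprising. Compound 4 is accordingly estimated at 50000 nM, with a range from 10000 nM to 200000 nM.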

Compound 4, half-maximal inhibitory concentration: 200000 nM
For compound 4 the middle estimate is 4.0-fold (0.60 log units) below the measured one; the measured number falls inside the stated range.
By their numbers in this assay, from the lowest: compounds 1, 2, 3 and 4 (each within the scatter of the next, the first and the last beyond it).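

Placing 1-(dimethylamino)ethyl where methyl stood, on an aromatic carbon para to a large group, gives a 1.4-fold higher number from compound 3 to compound 4 (0.15 log units; within the scatter) in this assay. So this position can carry a group of 5 heavy atoms, including a nitrogen, in place of a single carbon without the number moving beyond the usual scatter. That swap does not lift the compound out of the weak region, and no supporting measurement here explains this result.

On these data alone, it remains open whether a carboxylic acid, a primary amine or a longer carbon chain at this same place would move the number beyond the scatter. As far as these compounds go, it is also open whether the same swap would give a similar step on the core of compound 1.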